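Series notes: configuration change at a ring methyl

The compounds below may be only part of what the source reports. "The series", "measured", "known", "first", "only" and "open" are said of these compounds alone.

Values in a functional assay on P388 cells (Mus musculus) for inhibition, with a stated time of 48 h, tested at 10 ug/mL; a lower number here means a weaker effect, a higher number a stronger effect of the compound at the concentration tested:
compound 1 `C=C1C(=O)O[C@H]2CCCCC[C@@H]12`: 102%
compound 2 `C=C1C(=O)O[C@H]2[C@@H](O)CCCC[C@@H]12`: 100%
compound 3 `C=C1C(=O)O[C@H]2CC[C@H](C)CC[C@@H]12`: 102%

Compound 3 stands level with compound 1 at the digits printed, and the two together give the highest of the three numbers. Its nearest neighbour on the numbers is compound 1, with no change at the digits printed from compound 1 to compound 3 (within the scatter). Its furthest is compound 2; there compound 2 gives 100%, which is within the scatter of what compound 3 gives, so no order between them can be read.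

Compound 4 `C=C1C(=O)O[C@H]2CC[C@@H](C)CC[C@@H]12` is the next member. The change from compound 3 is the two compounds have the same atoms and bonds and differ only in configuration as drawn: 1 of 3 stereo elements differ; a stereocentre at a saturated ring carbon is drawn R in compound 3 and S in compound 4. Within the data shown here, no measured step changes a configuration alone, so no step bears on it directly. The steps that come nearest are the introduction of the same methyl, no change at the digits printed from compound 1 to compound 3 (within the scatter), and the introduction of the hydroxy, a number 2 percentage points lower from compound 1 to compound 2 (within the scatter); both sit within the scatter. Since placing the methyl on the ring left the read-out in this assay unchanged, the expectation for redrawing its configuration is a step of no more than a number 2 percentage points lower from compound 3 to compound 4 (within the scatter), with no direction beyond the scatter. Compound 4 is therefore estimated at 100%, with a range from 90% to 106%.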

Compound 4, a percentage reported as activity, at one concentration (the size of the read-out at that concentration, not a potency): 101%
The estimate for compound 4 lay 1 percentage points below the measured number; the measured number falls inside the stated range.
By their numbers in this assay, from the lowest: compounds 2, 4, 1 and 3 (each within the scatter of the next).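

Among these compounds, compounds 3 and 4 are the one pair here that isolates configuration at the ring methyl: the fact that compounds 3 and 4 differ only in the configuration as drawn.

In this assay, among the compounds shown here, redrawing that stereocentre from R to S gives a number 1 percentage points lower from compound 3 to compound 4 (within the scatter) and is the first measured step to change configuration alone, so at this concentration the read-out does not tell the two drawings of the methyl apart. Measured against the shared core without the methyl, the S-drawn compound gives a number 1 percentage points lower from compound 1 to compound 4 (within the scatter) and this joins the step already seen for the R-drawn methyl, so the methyl in either configuration stays within the scatter of compound 1 in this assay.

On these data alone, the read-out is a size of effect at a single concentration and not a potency, and all four compounds sit close together on it, so it remains open whether the two methyl configurations would separate at a lower concentration. Also open, as far as these compounds go, is whether an amine, a carboxylic acid or a longer chain in place of the methyl on this saturated ring carbon would move the read-out beyond the scatter, and whether configuration would then count.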